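The source may hold more compounds than are shown below. What is called first, only, known or untested is meant among the compounds shown, and "the series" means these compounds.

Measured so far in a functional assay on cells for agonist activity at Free fatty acid receptor 1 (Mus musculus), read by FLIPR and calcium flux, with a stated time of 5 min; on this read-out lower numbers stand for smaller maximal responses and higher numbers for larger maximal responses:
compound 1, `Cc1nn(-c2ccccn2)c2cc(-c3ccc(CCC(=O)O)cc3)ccc12`: 95%
compound 2, `Cc1nn(-c2ccccn2)c2cc(-c3ccc(CC(C)(C)C(=O)O)cc3)ccc12`: 18%

Compound 2 stands lowest of the two numbers; its nearest neighbour is compound 1, which sits higher by a number 77 percentage points lower from compound 1 to compound 2 (beyond the scatter) read in reverse. Compound 3, `Cc1nn(-c2ccccn2)c2cc(-c3ccc(CCCC(=O)O)cc3)ccc12`, is not yet measured. It differs from compound 2 by 2-carboxyethyl in place of 1-carboxy-1-methylethyl on a saturated chain carbon bound to an aromatic carbon. Going by the values given here, the only measured step that bears on this change is the one from compound 1 to compound 2, a number 77 percentage points lower from compound 1 to compound 2 (beyond the scatter), in which the two methyl groups on the chain carbon appeared and the maximal response fell sharply. Among the compounds with values here, compound 3 undoes that branching, though with the carboxy group one bond further out than in compound 1; no measured pair speaks to chain length alone. A large upward step in this assay is therefore expected, estimated as a number 62 percentage points higher from compound 2 to compound 3 (beyond the scatter). For compound 3 the maximal response in this assay is estimated at 80%, within 50% to 105%.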

Compound 3, largest response reached (reported as efficacy), in percent of the reference or control that the assay uses: 117%
Compound 3: middle estimate off by 37 percentage points, on the low side; measured number outside the range, above it.
By their numbers in this assay, from the lowest: compound 2; then compound 1; then compound 3.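

In this assay, the longer unbranched chain does more than recover the loss seen with branching: a number 99 percentage points higher from compound 2 to compound 3 (beyond the scatter), and the further gain over the shorter unbranched chain is a number 22 percentage points higher from compound 1 to compound 3 (beyond the scatter). Chain length at this position therefore has its first direct reading, and compound 3 stands highest of the three, with both of its steps beyond the scatter. Nothing available explains either step.

The step from compound 2 to compound 3 changes branching and chain length together, so the share of each stays unresolved, and a single methyl group on the chain carbon would be needed to separate them. Going by these compounds, whether the response keeps rising with a still longer chain ending in a carboxylic acid, or holds with an amide in place of that acid, also remains open.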